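Replacing Phenoxy with an Open Chain

The source may hold more compounds than are shown below. What is called first, only, known or untested is meant among the compounds shown, and "the series" means these compounds.

Compound 1 `O=C(Nc1ccccc1)c1cnc(NCc2c(F)ccc3c2CCO3)n2cnnc12`, compound 2 `O=C1c2ccccc2CN1c1cnc(NCc2c(F)ccc3c2CCO3)n2cnnc12` and compound 3 `Fc1ccc2c(c1CNc1ncc(Oc3ccccc3)c3nncn13)CCO2` share a core and were tested in a physicochemical assay for solubility, read by LC-MS, in phosphate buffer, with a stated time of 24 h, at pH 7.4; a lower number here means a less soluble compound, a higher number a more soluble compound. Compound 1 reports only a limit, < 1000 nM. Compound 2 gives 4000 nM. Compound 3 gives 8000 nM, so it stands level with compound 2 at the top of the numbers, with a 2.0-fold higher number from compound 2 to compound 3 (0.30 log units; within the scatter). Compound 4 `COCCC(=O)Nc1cnc(NCc2c(F)ccc3c2CCO3)n2cnnc12` carries ((2-methoxyethyl)carbonyl)amino in place of phenoxy on an aromatic carbon. Changes at this place have mattered before, with an at least 8.0-fold higher number from compound 1 to compound 3 (0.90 log units; beyond the scatter) and an at least 4.0-fold higher number from compound 1 to compound 2 (0.60 log units; beyond the scatter). Yet every measured group holds a ring and the entering chain has none, so these steps set no direction. The expected change is a 1.3-fold higher number from compound 3 to compound 4 (0.10 log units; within the scatter), with no step beyond the scatter. Compound 4 is estimated at 10000 nM, within an expected range of 2500 nM to 40000 nM.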

Compound 4, solubility: 980000 nM
Compound 4: the middle estimate sits 98-fold (1.99 log units) below what was measured; measured number above the stated range.
By their numbers in this assay, from the lowest: compounds 2 and 3 (each within the scatter of the next); then compound 4. At a limit, below all of these: compound 1.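

In this assay, this position proves able to move the number far more than the ring-bearing groups suggested: the open chain ((2-methoxyethyl)carbonyl)amino gives large steps (a 120-fold higher number from compound 3 to compound 4 (2.09 log units; beyond the scatter)) and (a 250-fold higher number from compound 2 to compound 4 (2.39 log units; beyond the scatter)). The remaining step rests on a limit (an at least 980-fold higher number from compound 1 to compound 4 (2.99 log units; beyond the scatter)). Nothing measured here bears on why the number climbs so far.

Going by these compounds, whether the rise follows the amide hydrogen, the ether oxygen or simply the missing ring stays open. A plain alkyl amide, a longer ether chain, an amine or a carboxylic acid at this place would help to separate these.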